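Urea in place of acetamide on the shared core

This account rests on a few compounds, and the source may have more. Where it says the series, first, only, none or still open, it means among the compounds named here.

Compound 2 `CC(=O)NC1Cc2ccc(NC(=O)c3ccccc3-c3ccc(C(F)(F)F)cc3)cc2C1` gives 80 nM in an assay on isolated protein for inhibition of microsomal triglyceride transfer protein large subunit (Homo sapiens) (a lower number here means a stronger inhibitor, a higher number a weaker inhibitor), the lower of the two numbers in hand. Compound 1 `Cc1cccc(C(=O)Nc2ccc3c(c2)CC(NS(=O)(=O)c2ccccc2)C3)c1-c1ccc(F)cc1` gives 240 nM in this assay, a gap beyond the usual scatter; the two differ in several places, so that gap is not tied to any single change. Compound 3 `CN(C)C(=O)NC1Cc2ccc(NC(=O)c3ccccc3-c3ccc(C(F)(F)F)cc3)cc2C1` carries dimethylamino in place of methyl on a carbonyl carbon, dimethylamino in place of methyl on a carbonyl carbon. For the measured compounds named here, no measured step of this kind exists, so the expected step of a 1.3-fold higher number from compound 2 to compound 3 (0.10 log units; within the scatter) is small, in no firm direction, and within the scatter. Compound 3 is estimated at 100 nM, within 35 nM to 300 nM.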

Compound 3, half-maximal inhibitory concentration: 80 nM
For compound 3 the middle estimate is 1.3-fold (0.10 log units) above the measured one; the range from low to high includes it.
By their numbers in this assay, from the lowest: compounds 2 and 3 (each within the scatter of the next); then compound 1.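

For the compounds shown here, this is the first single-place step. In this assay it reads no change at the digits printed from compound 2 to compound 3 (within the scatter), so on this carbonyl carbon, acetamido can give way to (dimethylcarbamoyl)amino with no shift beyond the scatter. No measured property of either group bears on this result.

Open, on these data alone, is how morpholine, methoxy or a longer chain would read on the same carbonyl carbon. Also open, as far as these compounds go, is whether the same change reads alike when the rest of the shared core carries other groups.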